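This account rests on a few compounds, and the source may have more. Where it says the series, first, only, none or still open, it means among the compounds named here.

In a functional assay on PC-3 cells (Homo sapiens) for antiproliferative activity, read by WST assay, with a stated time of 3 days (a lower number here means a stronger inhibitor, a higher number a weaker inhibitor), two numbers stand so far. Compound 1 (`CCN(CC)CCCCOc1c(-c2cc(OC)c(OC)c(OC)c2)oc2ccccc2c1=O`) gives 13700 nM and compound 2 (`CCN(CC)CCCCCOc1c(-c2cc(OC)c(OC)c(OC)c2)oc2ccccc2c1=O`) gives 6600 nM as the lower of the two.

The next structure is compound 3 (`CCCCN(CCCC)CCCOc1c(-c2cc(OC)c(OC)c(OC)c2)oc2ccccc2c1=O`). Relative to compound 2 it carries dibutylamino in place of 2-(diethylamino)ethyl on a saturated chain carbon, three bonds along the chain from an oxygen on an aromatic ring as its difference, which, cut one bond further out, reads 5-(diethylamino)pentyl to 3-(dibutylamino)propyl. The chain therefore shortens while dibutylamino replaces diethylamino.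

Among the measured compounds shown here, only one measured step bears on this, and only on the chain: a 2.1-fold lower number from compound 1 to compound 2 (0.32 log units; beyond the scatter) is modest, lies just beyond the scatter and runs toward the longer chain. Taken alone, that step would lead to an expected number for compound 3 somewhat higher than that of compound 2. For the measured compounds named here, no measured pair shows the exchange of diethylamino for dibutylamino, so that part of the change has no data behind it.

No step beyond the scatter is expected, and the estimated 1.3-fold lower number from compound 2 to compound 3 (0.12 log units; within the scatter) is a weak call in either direction. For compound 3 the estimate is 5000 nM in this assay with an expected range from 1800 nM to 14000 nM as its limits.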

Compound 3, half-maximal inhibitory concentration: 7100 nM
The estimate for compound 3 lay 1.4-fold (0.15 log units) below the measured number; measured number inside the range.
By their numbers in this assay, from the lowest: compounds 2, 3 and 1 (each within the scatter of the next, the first and the last beyond it).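

In this assay, replacing 5-(diethylamino)pentyl with 3-(dibutylamino)propyl gives a 1.1-fold higher number from compound 2 to compound 3 (0.03 log units; within the scatter), so the shorter chain carrying dibutylamino cannot be told apart from the longer chain carrying diethylamino. The comparison with the butyl chain gives a 1.9-fold lower number from compound 1 to compound 3 (0.29 log units; within the scatter), also within the scatter, so compound 3 sits level with both diethylamino compounds even though those two stand apart from each other. The change at this position joins a different chain length to a different amine, and the flat result may reflect little effect from either or two effects that offset each other; no supporting data bear on which applies.

Still open, going by these compounds, is how dibutylamino behaves on its own, which a 3-(diethylamino)propyl chain or a 5-(dibutylamino)pentyl chain on the shared core would help to separate from the effect of chain length. Also open, on these data alone, is whether a cyclic amine such as piperidine or morpholine at the chain end would move the number beyond the scatter from the open-chain amines.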